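A few compounds are considered here, and "the series" means these few. Any claim that something is new, unique, unknown or untested is made for them only; others in the source may bear on it.

Compound 1 `Cn1ccc2c(Oc3ccc(NC(=O)c4nn(-c5ccc(Br)cc5)ccc4=O)cc3)ccnc21` gives 16300 nM in a functional assay on MCF7 cells (Homo sapiens) for cytotoxicity, read by MTT assay, with a stated time of 72 h; a lower number here means a stronger inhibitor, a higher number a weaker inhibitor. Compound 2 `Cc1cc(=O)n(-c2ccccc2OC(F)(F)F)nc1C(=O)Nc1ccc(Oc2ncnc3[nH]ccc23)cc1` gives 32000 nM. Compound 3 `Cc1cc(=O)n(-c2ccccc2OC(F)(F)F)nc1C(=O)Nc1ccc(Oc2ncnc3c2ccn3C)cc1` gives 27000 nM.

Compound 3 stands second highest of these three numbers, but all three lie within the scatter of one another, so no order can be drawn among them. Going by the values given here, the one measured step, a 1.2-fold lower number from compound 2 to compound 3 (0.07 log units; within the scatter), is also within the scatter. Compound 4 `Cc1cc(=O)n(-c2ccccc2C(F)(F)F)nc1C(=O)Nc1ccc(Oc2ncnc3c2ccn3C)cc1` differs from compound 3 by trifluoromethyl in place of trifluoromethoxy on an aromatic carbon. Among the compounds with values here, no measured step touches this change, so nothing here points to a shift in either direction. In this assay compound 4 is therefore expected to give about 25000 nM, in a range from 8000 nM to 80000 nM. The expected step, a 1.1-fold lower number from compound 3 to compound 4 (0.03 log units; within the scatter), stays within the scatter.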

Compound 4, half-maximal inhibitory concentration: 7840 nM
Estimate against measurement, compound 4: 3.2-fold (0.50 log units) above, outside the stated range (below it).
By their numbers in this assay, from the lowest: compound 4; then compounds 1, 3 and 2 (each within the scatter of the next).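

The step of a 3.4-fold lower number from compound 3 to compound 4 (0.54 log units; beyond the scatter) in this assay is the first one among these compounds that lies beyond the scatter. It shows that this place on the six-membered aromatic ring of carbon only can move the number, even though trifluoromethyl and trifluoromethoxy differ by a single oxygen as they are named. No measurement here bears on the reason for this shift. Still open, going by these compounds, is how an amine or a nitrile at this place would read, and whether the same change would give a similar step on the core of compound 2.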